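Aryl replacement at the shared core: compound 2 to compound 3

The source may hold more compounds than are shown below. What is called first, only, known or untested is meant among the compounds shown, and "the series" means these compounds.

For the measured compounds named here, in a functional assay on Jurkat cells for inhibition of nuclear factor NF-kappa-B complex (Homo sapiens) (a higher number here means a weaker inhibitor, a lower number a stronger inhibitor), compound 2 `CCOC(=O)c1cnc(-c2ccncc2)nc1NN1C(=O)C=C(C)C1=O` gives 6000 nM, the highest of the two numbers so far; its nearest neighbour, compound 1 `CCOC(=O)c1cnc(SC)nc1NN1C(=O)C=C(C)C1=O`, gives 200 nM in this assay. Going by the values given here, the one step measured is a 30-fold higher number from compound 1 to compound 2 (1.48 log units; beyond the scatter), where pyridin-4-yl on the aromatic carbon between two ring nitrogen atoms replaced methylsulfanyl. Compound 3 `CCOC(=O)c1cnc(-c2ccc(Cl)cc2)nc1NN1C(=O)C=C(C)C1=O` differs from compound 2 by 4-chlorophenyl in place of pyridin-4-yl on an aromatic carbon. Among the compounds with values here, no measured step compares pyridin-4-yl with 4-chlorophenyl at this place, so the step from compound 1 to compound 2 bears on it only indirectly: it shows an aromatic group here at a much higher number than methylsulfanyl. Compound 3 keeps an aromatic group there, so the number is expected to stay near compound 2, with a 1.7-fold lower number from compound 2 to compound 3 (0.23 log units; within the scatter). For compound 3 the estimate in this assay is 3500 nM, ranging from 800 nM to 15000 nM.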

Compound 3, half-maximal inhibitory concentration: 300 nM
Beside the measured number, compound 3's estimate is 12-fold (1.07 log units) above it; measured number below the stated range.
By their numbers in this assay, from the lowest: compounds 1 and 3 (each within the scatter of the next); then compound 2.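

At the aromatic carbon between two ring nitrogen atoms, an aromatic group does not in itself go with a high number in this assay, as the step with 4-chlorophenyl in place of pyridin-4-yl shows: a 20-fold lower number from compound 2 to compound 3 (1.30 log units; beyond the scatter), a change as large as the one seen earlier in the opposite direction. With a 1.5-fold higher number from compound 1 to compound 3 (0.18 log units; within the scatter), 4-chlorophenyl and methylsulfanyl lie within the scatter of each other, so among the three groups only pyridin-4-yl stands apart at this position. Nothing measured here accounts for the gap between pyridin-4-yl and 4-chlorophenyl.

The compounds shown leave open whether this step follows the loss of the ring nitrogen or the arrival of the chlorine, which a plain phenyl group at this carbon would separate. Also open, on these data alone, is how an amine, or a longer alkyl chain on the sulfur, would read in this assay at this position.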